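Methyl on the anilino ring of the shared core

This account rests on a few compounds, and the source may have more. Where it says the series, first, only, none or still open, it means among the compounds named here.

Compound 1 `CCOC(=O)c1c(-c2ccc(Cl)cc2)cc(-c2ccccc2)nc1N1CCCCC1`, compound 2 `CCOC(=O)c1c(-c2ccc(Cl)cc2)cc(-c2ccccc2)nc1N1CCN(C)CC1` and compound 3 `CCOC(=O)c1c(-c2ccc(Cl)cc2)cc(-c2ccccc2)nc1Nc1ccccc1` share one core and differ only in the amine attached to an aromatic carbon. In a functional assay on the whole organism (strain Wister albino) for inhibition, with Rattus norvegicus as the target, read by paw edema, with a stated time of 1 h, at a dose of 50 mg/kg by the intraperitoneal route (on this read-out lower numbers stand for less inhibition and higher numbers for more inhibition at the one dose given (going by the name of the read-out)), compound 1 gives 59.3%, compound 2 gives 65.8% and compound 3 gives 62.3%. The three steps among them, a number 6.5 percentage points higher from compound 1 to compound 2 (within the scatter), a number 3 percentage points higher from compound 1 to compound 3 (within the scatter) and a number 3.5 percentage points lower from compound 2 to compound 3 (within the scatter), all stay within the scatter, so the three numbers cannot be ordered. On the bare numbers compound 3 stands second of the three, with compound 1 nearest and compound 2 furthest.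

Compound 4 `CCOC(=O)c1c(-c2ccc(Cl)cc2)cc(-c2ccccc2)nc1Nc1ccc(C)cc1` keeps the anilino group of compound 3 and adds to it; the change is methyl in place of hydrogen on an aromatic carbon. Among the measured compounds shown here, none of the measured steps touches the anilino ring: each exchanges the whole amine, and each lies within the scatter. For the measured compounds named here, the data therefore offer no step that bears on this change, and no step beyond the scatter is expected in this assay for compound 4. Compound 4 is estimated at 62%, between 50% and 74%, which means an expected step of a number 0.3 percentage points lower from compound 3 to compound 4 (within the scatter).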

Compound 4, a percentage reported as inhibition, in the whole organism at one dose (the size of the read-out at that dose, not a potency): 69.5%
Estimate against measurement, compound 4: 7.5 percentage points below; the range from low to high includes it.
By their numbers in this assay, from the lowest: compounds 1, 3, 2 and 4 (each within the scatter of the next, the first and the last beyond it).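

In this assay, among the compounds shown here, methyl in place of hydrogen on the anilino ring, para to a large group, gives the first reading at this position (a number 7.2 percentage points higher from compound 3 to compound 4 (within the scatter)), so no effect of the methyl can be claimed. Against the other amines, the series shows one step within the scatter (a number 3.7 percentage points higher from compound 2 to compound 4 (within the scatter)) and its first beyond it (a number 10.2 percentage points higher from compound 1 to compound 4 (beyond the scatter)), a modest separation of compound 4 from compound 1 alone. Nothing measured in the series accounts for any of these steps.

Only methyl is shown on the anilino ring, so a chlorine, a methoxy or a hydroxyl at this place remains open. Also open, from the compounds shown here alone, is whether a carboxylic acid in place of the ethyl ester on the shared core would leave the read-out within the scatter.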